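From compound 3 to compound 4: an unread step

The source may report more compounds than this note shows. Statements on the series, on what has been measured and on what is new or still open speak of the compounds shown alone.

Measured so far in an ADME assay on a cell-free system (plasma, Homo sapiens) for metabolic stability, at 37 degrees C; on this read-out higher numbers stand for a longer-lived compound and lower numbers for a shorter-lived compound:
- compound 1 `CCC/N=C1\S/C(=C\c2ccc(C(=O)OC)cc2)C(=O)N1c1ccccc1C`: > 3 h (a limit)
- compound 2 `CCC/N=C1\S/C(=C\c2ccc(C(=O)NCC(=O)N(C)C)cc2)C(=O)N1c1ccccc1O`: > 3 h (a limit)
- compound 3 `CCC/N=C1\S/C(=C\c2ccc(C(=O)OCCCO)cc2)C(=O)N1c1ccccc1O`: > 3 h (a limit)

Compound 3 stands at a limit (> 3 h), not at a number. Within the data shown here, the whole series so far rests on one reading (the limit of > 3 h in this assay, at which 3 of the 3 values shown sit), so nothing on the numbers sets compound 3 apart from the other two compounds.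

Compound 4 `CCC/N=C1\S/C(=C\c2ccc(C(=O)OCC3COC(=O)O3)cc2)C(=O)N1c1ccccc1O` carries 2-oxo-1,3-dioxolan-4-yl in place of 2-hydroxyethyl on a saturated chain carbon bound to an oxygen next to a carbonyl group. Among the measured compounds shown here, only one measured step touches the same carbonyl carbon (a step that the two limits leave unreadable from compound 2 to compound 3), where 3-hydroxypropoxy took the place of ((dimethylcarbamoyl)methyl)amino. Its size cannot be read, and so it offers no size or direction to carry over. For the measured compounds named here, no measured compound carries the entering group.

No step beyond the usual scatter is therefore expected, in either direction, though this expectation is weakly founded. The estimated step is small (a step that the limit leaves unreadable from compound 3 to compound 4). In this assay compound 4 is estimated at 3.5 h (expected range 1.2 h to 10 h).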

Compound 4, half-life in the Homo sapiens assay: 1.02 h
Beside the measured number, compound 4's estimate is 3.4-fold (0.54 log units) above it; the whole stated range lies above it.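

In the Homo sapiens assay, 2-oxo-1,3-dioxolan-4-yl in place of 2-hydroxyethyl gives an at least 2.9-fold lower number from compound 3 to compound 4 (0.46 log units; beyond the scatter), and (2-oxo-1,3-dioxolan-4-yl)methoxy in place of ((dimethylcarbamoyl)methyl)amino on a carbonyl carbon gives an at least 2.9-fold lower number from compound 2 to compound 4 (0.46 log units; beyond the scatter), so the number at this position does respond to the group placed there. Among these compounds, the steps among the earlier compounds cannot be read, as those compounds all rest on one limit of the assay: the limit of > 3 h in the Homo sapiens assay, at which 3 of the 4 values shown sit. In a physicochemical assay for lipophilicity, read by HPLC, measured as chromatographic lipophilicity (a higher number here means a more lipophilic compound, a lower number a more polar compound), compound 3 gives 2.3 and compound 4 gives 2.8. In the physicochemical assay the same change gives a number 0.50 log units higher from compound 3 to compound 4 (beyond the scatter), so here the lower half-life comes with a more lipophilic compound, though a single pair cannot tie the two together: the measured distribution coefficient of compound 3, 2.3, and of compound 4, 2.8, a number 0.50 log units higher (beyond the scatter).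

The compounds shown leave open whether the lower half-life follows the five-membered ring itself or the loss of the hydroxyl group, a question that a 2-methoxyethyl or a tetrahydrofuran-2-yl group on the same saturated chain carbon could help to settle. They also leave open how far the half-lives of compound 2 and compound 3 extend past their limit, and so how large the step truly is.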